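The source may hold more compounds than are shown below. What is called first, only, known or untested is meant among the compounds shown, and "the series" means these compounds.

Compound 1 `C/C(=N\NC(N)=S)c1ccc2[nH]c(-c3ccccc3)nc2c1` and compound 2 `COc1ccc(-c2nc3cc(/C(C)=N/NC(N)=S)ccc3[nH]2)cc1` share a core and differ in one place: methoxy in place of hydrogen on an aromatic carbon. In an ADME assay on MDBK cells (Bos taurus) for cytotoxicity, read by MTT assay, with a stated time of 96 h (on this read-out higher numbers stand for lower toxicity in this test and lower numbers for higher toxicity in this test), compound 1 gives 32000 nM, while compound 2 gives 13000 nM, so that the change made a 2.5-fold lower number from compound 1 to compound 2 (0.39 log units; beyond the scatter). Compound 3 `COc1ccc(-c2nc3cc(/C(C)=N/NC(N)=O)ccc3n2C2CCCCC2)cc1` carries a different core; the difference between the two cores is not broken down here. In this assay compound 3 gives 54000 nM, the highest of the three numbers, within the scatter of compound 1 and beyond it from compound 2.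

Compound 4 `COc1ccc(-c2nc3cc(/C(C)=N/NC(N)=O)ccc3n2C2CCCCC2)c(OC)c1` is the unmeasured partner of compound 3, from which it differs by methoxy in place of hydrogen on an aromatic carbon. This is the same kind of change as that from compound 1 to compound 2, but not the same: here the methoxy enters ortho to a large group and meta to a methoxy group, whereas in the earlier pair it entered para to a large group. Because the earlier step was a 2.5-fold lower number from compound 1 to compound 2 (0.39 log units; beyond the scatter), the step from compound 3 to compound 4 is expected to be a 1.9-fold lower number from compound 3 to compound 4 (0.29 log units; within the scatter), with wider uncertainty given the changed surroundings. Compound 4 is thus estimated at 28000 nM, between 11000 nM and 70000 nM.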

Compound 4, half-maximal cytotoxic concentration: 36000 nM
Compound 4: the middle estimate sits 1.3-fold (0.11 log units) below what was measured; the measured number falls inside the stated range.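

In this assay, methoxy in place of hydrogen on an aromatic carbon gave a 1.5-fold lower number from compound 3 to compound 4 (0.18 log units; within the scatter), so on this core the change cannot be told apart from the usual scatter of repeated measurements. Set beside the earlier step on the other core, the two readings do not separate from each other: the same change on two cores in this assay, a 2.5-fold lower number (0.39 log units; beyond the scatter) from compound 1 to compound 2 and a 1.5-fold lower number (0.18 log units; within the scatter) from compound 3 to compound 4, 1.6-fold (0.22 log units) apart, within the scatter of two such steps. Within the data shown here, this shows that the two cores give no detectable difference in the size of the step, but it does not show that the step is the same on both, as only two pairs are available, the methoxy enters a different place in each, and only the earlier step lies beyond the scatter.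

The compounds shown leave open whether another group in this place, such as an ethoxy group, an amine or a carboxylic acid, would give a step beyond the scatter on either core. They also leave open what each difference between the two cores contributes on its own.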